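The compounds below may be only part of what the source reports. "The series", "measured", "known", "first", "only" and "open" are said of these compounds alone.

In a toxicity assay on NIH3T3 cells (Mus musculus) for cytotoxicity, read by resazurin assay (on this read-out lower numbers stand for an effect already at smaller amounts and higher numbers for an effect only at larger amounts of compound), compound 1 `COC(=O)c1ccc(NCc2cncn2Cc2cccc([N+](=O)[O-])c2)cc1-c1ccccc1` shows only a limit, > 10000 nM. Compound 2 `Cc1ccccc1-c1cc(NCc2cncn2Cc2ccc(-c3ccccc3)cc2)ccc1-c1nc2ccccc2s1` likewise gives only a limit in this assay, > 1000 nM. Where compound 1 stands is therefore known only as a limit, one of the two limits described by the limit of > 1000 nM in this assay, at which 1 of the 2 values shown sits, and (the limit of > 10000 nM in this assay, at which 1 of the 2 values shown sits). Compound 3 `COC(=O)c1ccc(NCc2cncn2Cc2cccc(C(C)(C)C)c2)cc1-c1ccccc1` differs from compound 1 by tert-butyl in place of nitro on an aromatic carbon. Among the compounds with values here, with no step measured between two numbered values, the step that the limit leaves unreadable from compound 1 to compound 3 is expected to stay within the scatter, and compound 3 is expected most likely to reach only a limit again. Compound 3 is estimated at 15000 nM, within 5000 nM to 50000 nM.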

Compound 3, half-maximal effective concentration: > 1000 nM
Compound 3: no number, only a limit; the forecaster's own chance of this, stated with the estimate: 80%; the middle value lies beyond the limit too.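

Within the data shown here, compound 1 and compound 3 each give only a limit in this assay, and no step between them can be read. The compounds shown leave open the concentration at which any of them would reach a half-maximal effect.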